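This account rests on a few compounds, and the source may have more. Where it says the series, first, only, none or still open, it means among the compounds named here.

Measured so far in a functional assay on the whole organism for inhibition, with Rattus norvegicus as the target, read by paw edema, in the formalin test, with a stated time of 1 h, at a dose of 100 mg/kg by the intraperitoneal route; a lower number here means less inhibition, a higher number more inhibition at the dose given (going by the name of the read-out):
Compound 1 `O=c1cc(CNc2nc(-c3cc4cc(Br)cc(Br)c4oc3=O)cs2)c2cc(Cl)ccc2[nH]1`: 13.8%
Compound 2 `Cc1cccc2c(CNc3nc(-c4cc5cc(Br)ccc5oc4=O)cs3)cc(=O)[nH]c12`: 8.76%
Compound 3 `O=c1cc(CNc2nc(-c3cc4cc(Br)cc(Br)c4oc3=O)cs2)c2ccc(Cl)cc2[nH]1`: 12.6%

Compound 3 sits second highest of the three numbers, yet its gaps to compound 1, the nearest, and to compound 2, the furthest, both fall within the usual scatter, so the three cannot be told apart on these results. Compound 4 `O=c1cc(CNc2nc(-c3cc4cc(Br)ccc4oc3=O)cs2)c2ccc(Cl)cc2[nH]1` has not yet been measured. It differs from compound 3 in one place: hydrogen in place of bromo on an aromatic carbon. Within the data shown here, no measured pair differs in a single place, so no measured step guides the expectation. Compound 2, which also carries a single bromo group, gives 8.76%, within the scatter of compound 3. The step in this assay is therefore expected to be small, a number 1.6 percentage points lower from compound 3 to compound 4 (within the scatter), perhaps slightly downward but not beyond the scatter. Compound 4 is estimated at 11%, ranging from 4% to 19%.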

Compound 4, a percentage reported as inhibition, in the whole organism at one dose (the size of the read-out at that dose, not a potency): 5.8%
The estimate for compound 4 lay 5.2 percentage points above the measured number; low and high end bracket the measured number.
By their numbers in this assay, from the lowest: compounds 4, 2, 3 and 1 (each within the scatter of the next).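

Among these compounds, compound 4 gives the first comparison in this assay between two compounds that differ in one place: hydrogen in place of the bromo group ortho to a fused ring gives a number 6.8 percentage points lower from compound 3 to compound 4 (within the scatter) at this dose. This bromo group is therefore not shown to matter here, since the two compounds cannot be told apart on these numbers. Nothing measured on these compounds bears on this step. Still open, going by these compounds, is whether a different group at this position, such as a methoxy group or an amine, would give a step beyond the scatter.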